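Amide-side substitution in the tert-butyl ketone series

The source may report more compounds than this note shows. Statements on the series, on what has been measured and on what is new or still open speak of the compounds shown alone.

Of the compounds shown here, three sharing one core have been measured in an assay on isolated protein for binding affinity to vitamin D3 receptor (Homo sapiens), with a stated time of 4 h; a higher number here means a weaker inhibitor, a lower number a stronger inhibitor. Compound 1 `CCN(CC)CCCNC(=O)c1ccc(C(CC)(CC)c2ccc(OCC(=O)C(C)(C)C)c(C)c2)n1CC` gives 863 nM. Compound 2 `CCn1c(C(=O)NCCN)ccc1C(CC)(CC)c1ccc(OCC(=O)C(C)(C)C)c(C)c1` gives 1010 nM, and compound 3 `CCn1c(C(=O)NCCN)ccc1C(CC)(CC)c1ccc(OCC(O)C(C)(C)C)c(C)c1` gives 194 nM. Compound 2 gives the highest number of the three: a 1.2-fold higher number from compound 1 to compound 2 (0.07 log units; within the scatter) is within the scatter, whereas a 5.2-fold lower number from compound 2 to compound 3 (0.72 log units; beyond the scatter) is beyond it.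

Compound 4 `CC[C@@H](C)[C@H](NC(=O)c1ccc(C(CC)(CC)c2ccc(OCC(=O)C(C)(C)C)c(C)c2)n1CC)C(=O)O` is not yet measured. It differs from compound 2 in one place: 1-carboxy-2-methylbutyl in place of 2-aminoethyl on an amide-type nitrogen. Within the data shown here, the only measured step that touches this part of the molecule is a 1.2-fold higher number from compound 1 to compound 2 (0.07 log units; within the scatter), which exchanged one chain substituent for another on the same amide side and moved the number within the scatter. The step of a 5.2-fold lower number from compound 2 to compound 3 (0.72 log units; beyond the scatter) lies elsewhere and does not bear on this change. Among the measured compounds shown here, no measured step introduces an acid group at this position, so the expectation rests on a single step of small size.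

For compound 4 a change of a 1.1-fold lower number from compound 2 to compound 4 (0.05 log units; within the scatter) in this assay is expected, with no clear direction beyond the scatter. Compound 4 is therefore estimated at 900 nM, within a range of 250 nM to 3500 nM.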

Compound 4, half-maximal inhibitory concentration: 564 nM
Estimate against measurement, compound 4: 1.6-fold (0.20 log units) above; measured number inside the range.
By their numbers in this assay, from the lowest: compound 3; then compounds 4, 1 and 2 (each within the scatter of the next).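

On the amide-type nitrogen, 1-carboxy-2-methylbutyl in place of 2-aminoethyl gives a 1.8-fold lower number from compound 2 to compound 4 (0.25 log units; within the scatter) and in place of 3-(diethylamino)propyl gives a 1.5-fold lower number from compound 1 to compound 4 (0.18 log units; within the scatter) in this assay. The earlier amide-side step compared only chains carrying an amine; with a carboxylic acid on a branched chain at this place, all three amide-side groups on the (tert-butyl)carbonyl compounds still lie within the scatter of one another. Nothing available accounts for this result.

Still open, as far as these compounds go, is whether the same change keeps this outcome when 1-hydroxy-2,2-dimethylpropyl replaces (tert-butyl)carbonyl. Also open, from the compounds shown here alone, is how a shorter carboxymethyl chain, a methyl ester of the acid or the opposite stereochemistry would read at this amide nitrogen.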